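A fluorine swap on the sulfur-linked benzyl group

A few compounds are considered here, and "the series" means these few. Any claim that something is new, unique, unknown or untested is made for them only; others in the source may bear on it.

Compound 1 `Cc1cc(Nc2ccc(C(=O)/C=C/c3ccc4ccccc4c3)cc2)n2nc(SCc3ccccc3)nc2n1`: 300 nM
Compound 2 `Cc1cc(Nc2ccc(C(=O)/C=C/c3ccc4ccccc4c3)cc2)n2nc(SCc3ccccc3C(F)(F)F)nc2n1`: 1240 nM

In a functional assay on SW-620 cells (Homo sapiens) for cytotoxicity, read by MTT assay, with stated times of 4 h and 72 h, tested at 5 uM (a lower number here means a stronger inhibitor, a higher number a weaker inhibitor), compound 2 has the higher of the two numbers (1240 nM), which makes it the weaker inhibitor. Compound 3 `Cc1cc(Nc2ccc(C(=O)/C=C/c3ccc4ccccc4c3)cc2)n2nc(SCc3ccc(F)cc3)nc2n1` carries 4-fluorophenyl in place of the 2-(trifluoromethyl)phenyl of compound 2 (4-fluorophenyl in place of 2-(trifluoromethyl)phenyl on a saturated chain carbon bound to a sulfur). For the measured compounds named here, only one measured step bears on this (a 4.1-fold higher number from compound 1 to compound 2 (0.62 log units; beyond the scatter)). Going by the values given here, compound 3 has no trifluoromethyl, so much of that step is expected to be undone, although no measured compound shows what 4-fluorophenyl does. The expected change in this assay is therefore towards a lower number (a 3.0-fold lower number from compound 2 to compound 3 (0.47 log units; beyond the scatter)). Compound 3 is estimated at 420 nM (range 170 nM to 1050 nM).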

Compound 3, half-maximal inhibitory concentration: 320 nM
Estimate against measurement, compound 3: 1.3-fold (0.12 log units) above; the measured number falls inside the stated range.
By their numbers in this assay, from the lowest: compounds 1 and 3 (each within the scatter of the next); then compound 2.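

In this assay, 4-fluorophenyl in place of 2-(trifluoromethyl)phenyl gives a clear change in the number (a 3.9-fold lower number from compound 2 to compound 3 (0.59 log units; beyond the scatter)). Fluoro in place of hydrogen on the ring gives no difference that can be told from the scatter (a 1.1-fold higher number from compound 1 to compound 3 (0.03 log units; within the scatter)), so at this position the benzyl ring tolerates that fluoro, while the trifluoromethyl compound stands apart. Nothing available explains this difference.

Compound 2 and compound 3 differ in both the group and its place on the ring, and these two changes cannot be separated here. From the compounds shown here alone, how a methoxy group or an amine on this ring would behave also remains open.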